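Replacing 3-cyanophenyl with (pyridin-4-yl)methyl on an amine nitrogen

A few compounds are considered here, and "the series" means these few. Any claim that something is new, unique, unknown or untested is made for them only; others in the source may bear on it.

Values from a toxicity assay on HeLa cells (Homo sapiens) for cytotoxicity, read by colorimetric assay, with a stated time of 72 h (on this read-out higher numbers stand for lower toxicity in this test and lower numbers for higher toxicity in this test), are these
Compound 1 `O=c1nc(N2CCC(Oc3ccc(OC(F)(F)F)cc3)CC2)sc2c([N+](=O)[O-])cc(C(F)(F)F)cc12` gives > 93000 nM as a limit
Compound 2 `O=c1nc(N2Cc3ccccc3[C@H](CO)C2)sc2c([N+](=O)[O-])cc(C(F)(F)F)cc12` gives 86400 nM as a number
Compound 3 `N#Cc1cccc(N2CCN(c3nc(=O)c4cc(C(F)(F)F)cc([N+](=O)[O-])c4s3)CC2)c1` gives > 108000 nM as a limit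

For compound 3 the result > 108000 nM is a limit of the assay, not a number. The result for compound 1 > 93000 nM is also a limit. Within the data shown here, compound 2 gives the only true number of the three, 86400 nM in this assay on the same high part of the scale, which stands for low toxicity in this test.

In compound 4 `O=c1nc(N2CCN(Cc3ccncc3)CC2)sc2c([N+](=O)[O-])cc(C(F)(F)F)cc12` the change (pyridin-4-yl)methyl in place of 3-cyanophenyl on an amine nitrogen in a ring puts (pyridin-4-yl)methyl in place of 3-cyanophenyl on an amine nitrogen in a ring. Among the measured compounds shown here, no two measured compounds differ in one place only, so there is no direct step to lean on. The three measured compounds carry quite different amine groups on the shared core, and even so compound 2 stays at 86400 nM in this high region. The expectation in this assay is therefore no step beyond the scatter, and another limit would not be surprising. The estimated change is an at least 1.2-fold lower number from compound 3 to compound 4 (0.10 log units; that floor lies within the scatter) in size and stays within that scatter. For compound 4 the expected half-maximal cytotoxic concentration is 85000 nM with an estimated range from 35000 nM to 130000 nM at the ends.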

Compound 4, half-maximal cytotoxic concentration: > 111000 nM
Compound 4 was reported as a limit (the forecaster's own chance of this, stated with the estimate: 50%); middle value at least 1.3-fold (0.11 log units) from the limit.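

In this assay compound 3 gives > 108000 nM, which is a limit of the assay and not a number. Compound 4 gives > 111000 nM, also a limit, so no step can be read between compound 3 and compound 4. Still open, going by these compounds, is whether (pyridin-4-yl)methyl in place of 3-cyanophenyl changes the true value in this assay at all.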